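A few compounds are considered here, and "the series" means these few. Any claim that something is new, unique, unknown or untested is made for them only; others in the source may bear on it.

Within the data shown here, compound 1, `ClCc1cccc(Cn2cnc3c(Cl)nc(Cl)nc32)c1`, is the only member of this set with a numerical read-out: in a functional assay on SNB-19 cells (Homo sapiens) for cytotoxicity, read by sulforhodamine B assay, with a stated time of 48 h (on this read-out lower numbers stand for higher toxicity in this test and higher numbers for lower toxicity in this test), compound 1 gives 8920 nM. Compound 3, `ClCc1ccc(Cn2cnc3c(Cl)nc(Cl)nc32)cc1`, is recorded in this assay only as a limit of the assay, > 100000 nM. Compound 2, `Nc1nc(Cl)c2ncn(Cc3ccccc3CCl)c2n1`, likewise gives in this assay only a limit, > 100000 nM, and no number. Compound 2 therefore stands at the edge of what the assay reports, and it is not alone there, since (the limit of > 100000 nM in this assay, at which 2 of the 3 values shown sit).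

Compound 4, `ClCc1ccccc1Cn1cnc2c(Cl)ncnc21`, has not yet been measured in this assay. It differs from compound 2 in one place: hydrogen in place of amino on an aromatic carbon. The amino group leaves, and a hydrogen enters on an aromatic carbon of a six-membered aromatic ring with two nitrogens, between two ring nitrogen atoms, meta to a chloro group. Among the measured compounds shown here, compound 4 also carries its chloromethyl group at a different place on the benzyl ring than compound 1 or compound 3, and no measured step connects those compounds to it.

Because compound 2 sits at the limit, any expected step can only be read as a move toward a number or as staying at the limit; the step from compound 2 to compound 4 is estimated as an at least 2.0-fold lower number from compound 2 to compound 4 (0.30 log units; that floor lies within the scatter), toward higher toxicity. For compound 4 the expected value in this assay is 50000 nM, with a range from 8000 nM to 100000 nM.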

Compound 4, concentration lethal to 50% of the cells: > 100000 nM
Compound 4: a limit, no number (the forecaster's own chance of this, stated with the estimate: 50%); middle value at least 2.0-fold (0.30 log units) away from the limit.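

Compound 2 and compound 4 both stand at a limit of this assay rather than at a number, so no step between them can be read: the limit of > 100000 nM in this assay, at which 3 of the 4 values shown sit.

The compounds shown leave open whether hydrogen in place of amino on an aromatic carbon changes the read-out in this assay at all, and by how much.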